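Replacing methoxy with chloro on an aryl sulfonate

The source may report more compounds than this note shows. Statements on the series, on what has been measured and on what is new or still open speak of the compounds shown alone.

Compound 1 (`CN1CCN(c2ccc(S(=O)(=O)Oc3cccc(Br)c3)cc2)C1=O`) and compound 2 (`COc1ccc(OS(=O)(=O)c2ccc(N3CCN(C)C3=O)cc2)cc1`) share one core and differ in a single aryl group on an oxygen. In a functional assay on HT-29 cells (Homo sapiens) for antiproliferative activity, read by sulforhodamine B assay, with a stated time of 48 h (on this read-out higher numbers stand for weaker inhibition and lower numbers for stronger inhibition), compound 1 gives 1300 nM as its half-maximal inhibitory concentration. Compound 2 stands at the limit of > 100000 nM in this assay, at which 1 of the 2 values shown sits, and its reading of > 100000 nM is a limit rather than a number.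

Within the data shown here, the one measured step is large, with an at least 76-fold higher number from compound 1 to compound 2 (1.88 log units; beyond the scatter) when 4-methoxyphenyl takes the place of 3-bromophenyl on an oxygen. Compound 3 (`CN1CCN(c2ccc(S(=O)(=O)Oc3ccc(Cl)cc3)cc2)C1=O`) has chloro in place of methoxy on an aromatic carbon, para to a large group (chloro in place of methoxy on an aromatic carbon), turning 4-methoxyphenyl into 4-chlorophenyl. That measured step bears on this change only in part, since it shows that swapping this aryl group can shift the read-out strongly, yet 4-chlorophenyl is not 3-bromophenyl. Losing the methoxy should still recover much of the gap, though perhaps not all of it. The expected change is an at least 20-fold lower number from compound 2 to compound 3 (1.30 log units; beyond the scatter) as a large step towards stronger inhibition. In this assay the estimate for compound 3 is 5000 nM with an expected range from 500 nM to 50000 nM as the likely span.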

Compound 3, half-maximal inhibitory concentration: 12000 nM
Compound 3: the middle estimate sits 2.4-fold (0.38 log units) below what was measured, and the stated range covers the measured number.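

With chloro in place of methoxy on an aromatic carbon, para to a large group, the read-out in this assay shows an at least 8.3-fold lower number from compound 2 to compound 3 (0.92 log units; beyond the scatter), so this single small group separates a compound with a measured number from one without. The reading of compound 2 is a limit and not a number: the limit of > 100000 nM in this assay, at which 1 of the 3 values shown sits. Chloro does not fully match the aryl group of compound 1, however, as 4-chlorophenyl in place of 3-bromophenyl on an oxygen gives a 9.2-fold higher number from compound 1 to compound 3 (0.97 log units; beyond the scatter), which shows that the choice among halogen-bearing aryl groups also changes the result.

The compounds shown cannot separate the effect of the halogen from that of its place on the ring, since 3-bromophenyl and 4-chlorophenyl differ in both, so it remains unclear whether bromo at the para place or chloro at the other place would close the gap. They also leave open how the series would read with an amine, a carboxylic acid or a nitrile at this position, or with a plain phenyl carrying no added group at all.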